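The source may report more compounds than this note shows. Statements on the series, on what has been measured and on what is new or still open speak of the compounds shown alone.

Working notes on a small series built on one shared core. For the measured compounds named here, in a functional assay on MGC-803 cells (Homo sapiens) for cytotoxicity, read by MTT assay, with a stated time of 72 h (a lower number here means a stronger inhibitor, a higher number a weaker inhibitor), compound 1 (`O=C1C(=Cc2ccc(Br)cc2)C(=O)N(c2ccc(Cl)cc2)N1c1ccc(Cl)cc1`) gives 16900 nM and sits at the low end of the numbers so far, level within the scatter with compound 2 (`COc1cc(C=C2C(=O)N(c3ccc(Cl)cc3)N(c3ccc(Cl)cc3)C2=O)cc(OC)c1OC`) at 17300 nM in the same read-out. Compound 3 (`CC(=C1C(=O)N(c2ccc(Cl)cc2)N(c2ccc(Cl)cc2)C1=O)c1ccc(O)cc1`) gives 42800 nM and lies beyond the scatter on the weaker side of compound 1.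

Still unmeasured is compound 4 (`COc1cccc(C=C2C(=O)N(c3ccc(Cl)cc3)N(c3ccc(Cl)cc3)C2=O)c1OC`), which keeps the core of compound 1 and changes one group: 2,3-dimethoxyphenyl in place of 4-bromophenyl on a double-bonded chain carbon bound to a double-bonded ring carbon (in words, 2,3-dimethoxyphenyl in place of 4-bromophenyl on a double-bonded chain carbon bound to a double-bonded ring carbon).

Going by the values given here, no measured pair differs in one place only, so the size of this step can only be judged indirectly. The closest guide is compound 2, which also bears methoxy groups on the phenyl at this place and reads 17300 nM in this assay without departing from compound 1. On that basis no change beyond the scatter is expected in this assay, with at most a slight drift towards weaker values. The expected step is small, a 1.2-fold higher number from compound 1 to compound 4 (0.07 log units; within the scatter) in the estimate. The estimated value for compound 4 is 20000 nM with an expected range from 10000 nM to 40000 nM in this read-out.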

Compound 4, half-maximal inhibitory concentration: 29600 nM
Compound 4: the middle estimate sits 1.5-fold (0.17 log units) below what was measured; the range from low to high includes it.
By their numbers in this assay, from the lowest: compounds 1, 2, 4 and 3 (each within the scatter of the next, the first and the last beyond it).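

In this assay, for the compounds shown here, a 1.8-fold higher number from compound 1 to compound 4 (0.24 log units; within the scatter) gives the first direct reading of a single change at this position, and it lies within the scatter. Replacing 4-bromophenyl with 2,3-dimethoxyphenyl on a double-bonded chain carbon bound to a double-bonded ring carbon therefore gives no difference that can be told apart from repeat variation, even though the entering group has more heavy atoms, no bromine and 2 hydrogen-bond acceptors where the leaving group has none. No supporting data on any property of these groups are available to bear on this result.

Still open, from the compounds shown here alone, is whether a different kind of group on the phenyl at this place, such as an amine or a carboxylic acid, would give a step beyond the scatter. The compounds shown also give no single-change step at any other place on the shared core, so how far this tolerance extends to the rest of the molecule cannot be judged.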